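The source may report more compounds than this note shows. Statements on the series, on what has been measured and on what is new or still open speak of the compounds shown alone.

Working notes on the series, followed in a functional assay on IGROV-1 cells (Homo sapiens) for cytotoxicity, read by sulforhodamine B assay, with a stated time of 48 h, tested at 1 uM; a higher number here means a weaker effect of the compound at the concentration tested, a lower number a stronger effect. Compound 1 `COc1ccc(-c2cc(/C=C/C(=O)c3ccc(N)cc3)[nH]n2)cc1` gives 89% in this assay. Compound 2 `COc1cc(-c2cc(/C=C/C(=O)c3ccc(Cl)c(Cl)c3)[nH]n2)cc(OC)c1OC` gives 99% in this assay. Compound 2 stands with the higher of the two numbers, but compound 1 sits within the scatter of it, so the two are read as alike: neither shows much of an effect at the concentration tested. Within the data shown here, no pair of measured compounds differs in one place only, so no size has been measured for any single exchange in this set.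

Compound 3 `COc1ccc(C(=O)/C=C/c2cc(-c3cc(OC)c(OC)c(OC)c3)n[nH]2)cc1` has not yet been measured in this assay. From compound 2 it differs as follows: 4-methoxyphenyl in place of 3,4-dichlorophenyl on a carbonyl carbon. Nothing measured here speaks to this exchange on its own. Both known numbers lie close together and high, and the expected change for the step is a number 5 percentage points lower from compound 2 to compound 3 (within the scatter), that is, none beyond the scatter. Compound 3 is accordingly expected to give about 94% in this assay, within a range from 80% to 106%.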

Compound 3, a percentage reported as activity, at one concentration (the size of the read-out at that concentration, not a potency): 101%
Estimate against measurement, compound 3: 7 percentage points below, within the range that was stated.
By their numbers in this assay, from the lowest: compounds 1, 2 and 3 (each within the scatter of the next, the first and the last beyond it).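

The exchange of 3,4-dichlorophenyl for 4-methoxyphenyl on a carbonyl carbon gives the first measured size for a single exchange in this set: in this assay the step is a number 2 percentage points higher from compound 2 to compound 3 (within the scatter). At this place, then, two aromatic rings of equal heavy-atom count, one carrying two chlorine atoms and the other an oxygen with one hydrogen-bond acceptor, cannot be told apart at the concentration tested, and neither compound 2 nor compound 3 shows much of an effect. No measurement at hand bears on why the exchange leaves the read-out within the scatter.

Still open, from the compounds shown here alone, is whether a carboxylic acid or a longer alkyl chain in place of the aromatic ring on this carbonyl carbon would move the number beyond the scatter, since both groups compared here are substituted phenyl rings. Also open, going by these compounds, is whether this exchange would read the same on another core or at a higher concentration, as this single step, taken at one concentration, speaks to neither.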